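A few compounds are considered here, and "the series" means these few. Any claim that something is new, unique, unknown or untested is made for them only; others in the source may bear on it.

Compound 2 `CCOC(=O)C1=C(C)NC(COC)=C(C(=O)OC)C1c1cccc([N+](=O)[O-])c1` and compound 1 `CCOC(=O)C1=C(C)NC(COC)=C(C(=O)OC)C1c1ccccc1[N+](=O)[O-]` share one core and differ only in the position of the nitro group on the phenyl ring. In a functional assay on HEK293 cells for antagonist activity at Voltage-dependent L-type calcium channel subunit alpha-1C (Oryctolagus cuniculus), read by FLIPR (on this read-out lower numbers stand for stronger inhibition and higher numbers for weaker inhibition), compound 1 gives 1760 nM, whereas compound 2 gives 14 nM; the step of a 130-fold lower number from compound 1 to compound 2 (2.10 log units; beyond the scatter) is the only one measured so far, so compound 2 stands as the lowest of the two numbers. Compound 3 `COCC1=C(C(=O)OC)C(c2cccc([N+](=O)[O-])c2)C(C(=O)OC)=C(C)N1` keeps the 3-nitrophenyl group and changes compound 2 only at the ester: hydrogen in place of methyl on a saturated chain carbon bound to an oxygen next to a carbonyl group. For the measured compounds named here, none of the measured steps touches this part of the molecule, so no direct guide exists; the single measured step concerns the nitro position, not the ester. On that basis compound 3 is expected to stay close to compound 2, with the step of a 1.6-fold higher number from compound 2 to compound 3 (0.20 log units; within the scatter) anticipated to lie within the scatter or only slightly beyond it toward a higher number. The estimate for compound 3 in this assay is 22 nM, with a range from 7 nM to 70 nM.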

Compound 3, half-maximal inhibitory concentration: 115 nM
For compound 3 the middle estimate is 5.2-fold (0.72 log units) below the measured one, outside the stated range (above it).
By their numbers in this assay, from the lowest: compound 2; then compound 3; then compound 1.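

In this assay the ester proves to be a position that matters: going from ethoxycarbonyl to methoxycarbonyl, with the 3-nitrophenyl group kept, gives an 8.2-fold higher number from compound 2 to compound 3 (0.91 log units; beyond the scatter) and so moves the number even though the change removes only a methyl. The earlier pair spoke only to the nitro position, and this new step is smaller than a 130-fold lower number from compound 1 to compound 2 (2.10 log units; beyond the scatter) but is still a real change at a separate part of the molecule. Nothing given here accounts for the step.

As far as these compounds go, it remains open whether a longer chain such as propyl, or a benzyl group, in place of the ethyl would lower or raise the number further, and how a carboxylic acid or an amide would read in place of the ester. Also open, from the compounds shown here alone, is whether ethyl to methyl gives a step of similar size when the 2-nitrophenyl group is present.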